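The compounds below may be only part of what the source reports. "The series", "measured", "known", "first", "only" and "open" are said of these compounds alone.

Compound 1 `Cc1nn(C)c(Oc2cccc(F)c2)c1/C=N\CCCCCOc1cc2oc(=O)cc(C)c2cc1Cl` gives 13400 nM in a functional assay on HepG2 cells (Homo sapiens) for antiproliferative activity, read by MTT assay, with a stated time of 72 h; a higher number here means a weaker inhibitor, a lower number a stronger inhibitor.
Compound 2 `Cc1nn(C)c(Oc2ccc(F)cc2)c1/C=N\CCCCCOc1cc2oc(=O)cc(C)c2cc1Cl` reaches only a limit of the assay, > 25000 nM.
Compound 3 `Cc1nn(C)c(Oc2ccc(Cl)cc2)c1/C=N\CCCCCOc1cc2oc(=O)cc(C)c2cc1Cl` gives 15300 nM.

Compound 3 stands at the highest of the two numbers, but its nearest neighbour, compound 1, sits close by: a 1.1-fold higher number from compound 1 to compound 3 (0.06 log units; within the scatter), within the scatter. Compound 4 `Cc1nn(C)c(Oc2ccc(Br)cc2)c1/C=N\CCCCCOc1cc2oc(=O)cc(C)c2cc1Cl` differs from compound 3 by bromo in place of chloro on an aromatic carbon. The one measured step at the same place, a halogen swap, is an at least 1.6-fold lower number from compound 2 to compound 3 (0.21 log units; that floor lies within the scatter), and its floor lies within the scatter; the other steps among these three compounds also stay within the scatter. So no step beyond the scatter is expected from compound 3 to compound 4: a 1.0-fold lower number from compound 3 to compound 4 (0.01 log units; within the scatter). Compound 4 is therefore estimated at 15000 nM, with a range from 6000 nM to 30000 nM.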

Compound 4, half-maximal inhibitory concentration: 13800 nM
Beside the measured number, compound 4's estimate is 1.1-fold (0.04 log units) above it, and the stated range covers the measured number.
By their numbers in this assay, from the lowest: compounds 1, 4 and 3 (each within the scatter of the next). At a limit, above all of these: compound 2.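

Bromo on this aromatic carbon, para to a large group, leaves the result in this assay within the scatter of chloro: a 1.1-fold lower number from compound 3 to compound 4 (0.04 log units; within the scatter). The 4-bromophenyl compound also stays level with the 3-fluorophenyl compound: a 1.0-fold higher number from compound 1 to compound 4 (0.01 log units; within the scatter). Against fluoro, the step reads an at least 1.8-fold lower number from compound 2 to compound 4 (0.25 log units; that floor lies within the scatter), and it starts from a limit of the assay, so only its floor is known: the limit of > 25000 nM in this assay, at which 1 of the 4 values shown sits.

The compounds shown leave open whether a group other than a halogen at this place, such as methoxy, an amine or a carboxylic acid, would move the number beyond the scatter.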